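A Secondary Amine in Place of a Tertiary One

The compounds below may be only part of what the source reports. "The series", "measured", "known", "first", "only" and "open" are said of these compounds alone.

This account concerns sulfonamides built on a bis(trifluoromethyl)phenyl core and tested in a functional assay on ASPC1 cells (Homo sapiens) for inhibition, read by MTT assay, with a stated time of 72 h; a higher number here means a weaker inhibitor of growth, a lower number a stronger inhibitor of growth. Compound 1 `O=S(=O)(NCCNCc1cccc2ccccc12)c1cc(C(F)(F)F)cc(C(F)(F)F)c1` gives 22000 nM in this assay. Compound 2 `O=S(=O)(NCCNCc1ccc(-c2ccccc2)cc1)c1cc(C(F)(F)F)cc(C(F)(F)F)c1` gives 2800 nM. Compound 3 `CN(CCCNS(=O)(=O)c1cc(C(F)(F)F)cc(C(F)(F)F)c1)Cc1ccccc1` gives 51000 nM, the highest number of the three: its nearest neighbour is compound 1, and its furthest is compound 2, with both gaps lying beyond the scatter.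

Compound 4 `O=S(=O)(NCCCNCc1ccc(Cl)cc1)c1cc(C(F)(F)F)cc(C(F)(F)F)c1` is not yet measured. It differs from compound 3 in one place: (4-chlorobenzyl)amino in place of benzyl(methyl)amino on a saturated chain carbon, three bonds along the chain from a sulfonamide nitrogen. For the measured compounds named here, no measured pair isolates this change, so no step can be read directly from the data. Compounds 1 and 2 both carry an amine with one hydrogen-bond donor and give lower numbers than compound 3, which points toward a move downward for compound 4. The step from compound 3 to compound 4 is therefore expected to be a 3.4-fold lower number from compound 3 to compound 4 (0.53 log units; beyond the scatter), beyond the scatter. On that basis compound 4 is estimated at 15000 nM, within a range from 5000 nM to 45000 nM.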

Compound 4, concentration for 50% growth inhibition: 3000 nM
Estimate against measurement, compound 4: 5.0-fold (0.70 log units) above; measured number below the stated range.
By their numbers in this assay, from the lowest: compounds 2 and 4 (each within the scatter of the next); then compound 1; then compound 3.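

In this assay, for the compounds shown here, a 17-fold lower number from compound 3 to compound 4 (1.23 log units; beyond the scatter) is the only step between measured compounds that differ in one place, and it shows that the number responds strongly to a change on a saturated chain carbon, three bonds along the chain from a sulfonamide nitrogen. The exchange of benzyl(methyl)amino for (4-chlorobenzyl)amino leaves the heavy-atom total and the six-membered aromatic ring of carbon in place, yet it removes a methyl and brings in a chlorine and a hydrogen-bond donor. Nothing measured here accounts for the size of this step.

The compounds shown leave open how the step divides between the methyl and the chlorine. A plain benzylamino group on the same chain would speak to that, as would a bromine or a methoxy group in place of the chlorine.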